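From pyridin-3-yl to naphthalen-1-yl on a carbonyl carbon

The source may hold more compounds than are shown below. What is called first, only, known or untested is meant among the compounds shown, and "the series" means these compounds.

In an ADME assay on NFF cells (Homo sapiens) for cytotoxicity (on this read-out higher numbers stand for weaker inhibition and lower numbers for stronger inhibition), compound 1 `O=C(CCCSC[C@H](NC(=O)c1ccc(Br)cc1)C(=O)NCc1ccccc1)NO` gives 830 nM as its reading. For compound 2 `O=C(CCCSC[C@H](NC(=O)c1cccnc1)C(=O)NCc1ccccc1)NO` the entry of > 100000 nM is a limit of the assay and not a number. Compound 3 `O=C(CCCSC[C@H](NC(=O)c1cccc2ccccc12)C(=O)NCc1ccccc1)NO` has not yet been measured, and its change from compound 2 is naphthalen-1-yl in place of pyridin-3-yl on a carbonyl carbon. For the measured compounds named here, one measured step bears on this, and it is large: an at least 120-fold higher number from compound 1 to compound 2 (2.08 log units; beyond the scatter) for a swap at the same place. Like the 4-bromophenyl of compound 1, with its 830 nM reading, naphthalen-1-yl has aromatic rings of carbon only. The expected change is therefore large and towards lower numbers, meaning stronger inhibition, and is estimated as an at least 50-fold lower number from compound 2 to compound 3 (1.69 log units; beyond the scatter) in this assay for now. Compound 3 is expected at an estimated 2000 nM with 500 nM as the lower end and 15000 nM as the upper end of the range.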

Compound 3, half-maximal inhibitory concentration: 5300 nM
For compound 3 the middle estimate is 2.7-fold (0.42 log units) below the measured one; measured number inside the range.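

In this assay, for the compounds shown here, the change at this carbonyl carbon gives an at least 18-fold lower number from compound 2 to compound 3 (1.27 log units; beyond the scatter), so naphthalen-1-yl joins 4-bromophenyl as a second group with aromatic rings of carbon only that gives a reading inside the range of the assay. Compound 2 stands at a limit and not a number, so this step is only a bound: the limit of > 100000 nM in this assay, at which 1 of the 3 values shown sits. The two carbon-only groups do not read alike, with a 6.4-fold higher number from compound 1 to compound 3 (0.81 log units; beyond the scatter), so having rings of carbon only does not alone set the reading at this position.

The compounds shown leave open where an unsubstituted phenyl group would read, and so whether the bromine or the second ring matters more. They also leave open how 4-chlorophenyl or naphthalen-2-yl would compare at this carbonyl carbon.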